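A Rearranged Substitution Pattern Toward Compound 4

The compounds below may be only part of what the source reports. "The series", "measured", "known", "first", "only" and "open" are said of these compounds alone.

Of the compounds shown here, three sharing one core have been measured in an assay on lysate for inhibition of phosphatidylcholine:ceramide cholinephosphotransferase 2 (Homo sapiens), read by HPLC, with stated times of 30 min and 2 h; on this read-out lower numbers stand for stronger inhibition and higher numbers for weaker inhibition. Compound 1 `O=C(Nc1cccnc1)c1ccccc1OCc1ccccc1` gives 3200 nM. Compound 2 `Cc1ccccc1COc1ccccc1C(=O)Nc1cccnc1`, which carries a methyl group in place of a hydrogen on an aromatic carbon, gives 1500 nM. Compound 3 `O=C(Nc1cccnc1)c1ccccc1OCc1cc(F)ccc1Cl` gives 740 nM, the lowest of the three numbers; the nearest is compound 2, the furthest compound 1.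

Compound 4 `Cc1ccc(Cl)cc1COc1ccccc1C(=O)Nc1cccnc1` differs from compound 3 in one place: 5-chloro-2-methylphenyl in place of 2-chloro-5-fluorophenyl on a saturated chain carbon bound to an oxygen on an aromatic ring. The measured steps that bear on this are the gain of a methyl group, a 2.1-fold lower number from compound 1 to compound 2 (0.33 log units; beyond the scatter), the gain of chlorine and fluorine together, a 4.3-fold lower number from compound 1 to compound 3 (0.64 log units; beyond the scatter), and the exchange of a methyl-bearing ring for the chlorine-and-fluorine-bearing one, a 2.0-fold lower number from compound 2 to compound 3 (0.31 log units; beyond the scatter). Compound 4 keeps a chlorine and brings back the methyl seen in compound 2 while losing the fluorine. Since the methyl step and the chloro-fluoro step each lowered the number modestly, compound 4 is expected to sit close to compound 3, perhaps slightly lower, and the step of a 1.2-fold lower number from compound 3 to compound 4 (0.09 log units; within the scatter) is expected to be small in this assay. Compound 4 is therefore estimated at 600 nM, with a range from 250 nM to 1500 nM.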

Compound 4, half-maximal inhibitory concentration: 1100 nM
The estimate for compound 4 lay 1.8-fold (0.26 log units) below the measured number; low and high end bracket the measured number.
By their numbers in this assay, from the lowest: compounds 3, 4 and 2 (each within the scatter of the next, the first and the last beyond it); then compound 1.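

Putting 5-chloro-2-methylphenyl in place of 2-chloro-5-fluorophenyl on the saturated chain carbon gives a 1.5-fold higher number from compound 3 to compound 4 (0.17 log units; within the scatter) in this assay and shows that a methyl group can take over from the fluorine-bearing pattern here without a readable change in the number. Gaining a chlorine on the methyl-bearing ring gives a 1.4-fold lower number from compound 2 to compound 4 (0.13 log units; within the scatter) and so adds nothing that can be read on top of the methyl, while 5-chloro-2-methylphenyl in place of phenyl gives a 2.9-fold lower number from compound 1 to compound 4 (0.46 log units; beyond the scatter) and makes this the third substituted ring, after those of compound 2 and compound 3, to lower the number relative to plain phenyl. Nothing available explains why these rings behave alike.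

The compounds shown leave open whether a ring carrying chlorine alone, with neither methyl nor fluorine, would match these results. Going by these compounds, they also carry only methyl, chlorine and fluorine on this ring, so what a methoxy group, an amine or a carboxylic acid would do at this position remains unknown.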